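The compounds below may be only part of what the source reports. "The series", "measured", "known", "first", "only" and "open" are said of these compounds alone.

Working notes on the series.

Compound 1 `CC(=O)N1c2ccccc2CCC1C(=O)Nc1cc(C(F)(F)F)cc(C(F)(F)F)c1` carries an acetyl group on the ring nitrogen of the shared core. In a functional assay on NCI-H23 cells (Homo sapiens) for cytotoxicity, read by sulforhodamine B assay, with a stated time of 72 h (on this read-out lower numbers stand for stronger inhibition of growth and higher numbers for weaker inhibition of growth), compound 1 gives only a limit, > 70000 nM, which is a limit of the assay and not a measured number; the evidence here is the limit of > 70000 nM in this assay, at which 1 of the 2 values shown sits. Where compound 1 stands on the scale is therefore known only from the side of weak growth inhibition, with no number to step from.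

Compound 2 `O=C(Nc1ccccc1C(F)(F)F)C1CCc2ccccc2N1C(=O)c1ccc(Cl)cc1` is the other measured member, with a chlorobenzoyl group on the ring nitrogen and a single trifluoromethyl on the anilide; in this assay compound 2 gives 307 nM. Among the measured compounds shown here, no step between compound 1 and compound 2 is computed, so their two values are simply placed side by side: one a limit, one a number.

Compound 3 `O=C(Nc1cc(C(F)(F)F)cc(C(F)(F)F)c1)C1CCc2ccccc2N1C(=O)c1ccccc1` is not yet measured. It differs from compound 1 by phenyl in place of methyl on a carbonyl carbon. Since compound 1 sits at a limit, the step of an at least 23-fold lower number from compound 1 to compound 3 (1.36 log units; beyond the scatter) that the estimate implies is expected to run towards stronger growth inhibition, but its size can only be bounded from one side. On that basis compound 3 is expected at about 3000 nM in this assay, within 400 nM to 30000 nM.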

Compound 3, concentration for 50% growth inhibition: 2130 nM
The estimate for compound 3 lay 1.4-fold (0.15 log units) above the measured number; low and high end bracket the measured number.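

Acetyl to benzoyl, with the rest of the structure unchanged, gives in this assay an at least 32-fold lower number from compound 1 to compound 3 (1.51 log units; beyond the scatter), the first single change in the series that can be seen to move the read-out. The change is phenyl in place of methyl on a carbonyl carbon whose other neighbour is an amide-type nitrogen in a ring, so this position does not merely tolerate the larger group: growth inhibition is stronger with one six-membered aromatic ring of carbon only and no added hydrogen-bond donors or acceptors. The size of the step is bounded from one side only, compound 1 being held at a limit of the assay: the limit of > 70000 nM in this assay, at which 1 of the 3 values shown sits.

The compounds shown leave open whether the aromatic ring itself matters on this carbonyl carbon, or whether a cyclohexyl ring or a longer chain such as butyl would read the same as phenyl. Compound 2 differs from compound 3 in two places, so the chlorine on its benzoyl cannot be read alone, and an amine or a carboxylic acid on that phenyl remains an open case.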